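Methyl for hydroxy on the seven-membered ring

The source may report more compounds than this note shows. Statements on the series, on what has been measured and on what is new or still open speak of the compounds shown alone.

Compound 1, `Cc1cc(C(=O)N2CCCCc3ccccc32)ccc1CNC(=O)NCC(=O)N1CCCC1`: 100 nM
Compound 2, `Cc1cc(C(=O)N2CCCC(O)c3ccccc32)ccc1CNC(=O)N1CCC[C@H]1C(=O)N(C)C`: 230 nM

Both compounds were tested in a functional assay on HEK293 cells for agonist activity at Vasopressin V2 receptor (Homo sapiens), read by a luciferase reporter and cAMP accumulation; a higher number here means that more compound is needed for the effect, a lower number that less compound is needed. Compound 1 gives 100 nM. Compound 2 gives 230 nM, the higher of the two numbers, and the gap between the two compounds is beyond the usual scatter, so compound 2 needs more material than compound 1 to reach the same effect. The two compounds differ in more than one place, so this gap cannot be tied to any single change.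

Compound 3, `Cc1cc(C(=O)N2CCCC(C)c3ccccc32)ccc1CNC(=O)N1CCC[C@H]1C(=O)N(C)C`, has not yet been measured. It differs from compound 2 in one place: methyl in place of hydroxy on a saturated ring carbon. Going by the values given here, no measured pair shows the effect of exactly this exchange, so there is no step to lean on. The expectation is that the change from compound 2 to compound 3 gives a step of a 1.3-fold lower number from compound 2 to compound 3 (0.11 log units; within the scatter), small and within the usual scatter, with the direction uncertain. The estimate for compound 3 in this assay is 180 nM, in a range from 60 nM to 600 nM.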

Compound 3, half-maximal effective concentration: 220 nM
Estimate against measurement, compound 3: 1.2-fold (0.09 log units) below, and the stated range covers the measured number.
By their numbers in this assay, from the lowest: compound 1; then compounds 3 and 2 (each within the scatter of the next).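

In this assay, putting methyl in place of hydroxy on a saturated ring carbon gives a 1.0-fold lower number from compound 2 to compound 3 (0.02 log units; within the scatter), so the numbers for these two compounds cannot be told apart. This is the first pair shown that differs in only one place, and it offers a direct look at this position of the seven-membered ring: a group with one hydrogen-bond donor and one acceptor leaves, a group with neither enters, and the read-out stays within the usual scatter for this pair. Nothing available explains why this exchange leaves the two numbers level.

One exchange at one position is a narrow base, and it does not show whether this carbon tolerates substitution in general, or whether the same result would hold with the rest of the molecule altered. The compounds shown leave open what an amine, a carboxylic acid or a longer chain such as ethyl would do on this carbon, and how the molecule would read with only hydrogen there and everything else as in compound 2.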